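This account rests on a few compounds, and the source may have more. Where it says the series, first, only, none or still open, it means among the compounds named here.

Measured so far in an ADME assay on Vero 76 cells (Chlorocebus sabaeus) for cytotoxicity, read by MTT assay, with a stated time of 96 h; a lower number here means that less compound is tolerated, a higher number that more compound is tolerated:
compound 1 `Cc1ccccc1C1CC(c2ccc(OCc3ccccc3)cc2)=NN1c1ccc(S(N)(=O)=O)cc1` gives 100000 nM;
compound 2 `NS(=O)(=O)c1ccc(N2N=C(c3ccc(OCc4ccccc4)cc3)CC2c2ccc(F)cc2)cc1` gives 90000 nM;
compound 3 `NS(=O)(=O)c1ccc(N2N=C(c3ccc(Oc4ccccc4)cc3)CC2c2ccc(F)cc2)cc1` gives 25000 nM.

Compound 3 stands lowest of the three; the step of a 3.6-fold lower number from compound 2 to compound 3 (0.56 log units; beyond the scatter) comes from phenyl in place of benzyl on an oxygen on an aromatic ring, and this is also how the core of compound 3 differs from the core of compound 2. Within the core of compound 2, the change 2-methylphenyl in place of 4-fluorophenyl on a saturated ring carbon gave the step of a 1.1-fold higher number from compound 2 to compound 1 (0.05 log units; within the scatter).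

Compound 4 `Cc1ccccc1C1CC(c2ccc(Oc3ccccc3)cc2)=NN1c1ccc(S(N)(=O)=O)cc1` is not yet measured. It differs from compound 3 by 2-methylphenyl in place of 4-fluorophenyl on a saturated ring carbon, the same change as from compound 2 to compound 1. Because a 1.1-fold higher number from compound 2 to compound 1 (0.05 log units; within the scatter) lay within the scatter, the step of a 1.1-fold higher number from compound 3 to compound 4 (0.03 log units; within the scatter) is expected to be of similar size. Compound 4 is therefore estimated at 27000 nM, between 13000 nM and 55000 nM.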

Compound 4, half-maximal cytotoxic concentration: 90000 nM
The estimate for compound 4 lay 3.3-fold (0.52 log units) below the measured number; the measured number lies above the stated range.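

In this assay, 2-methylphenyl in place of 4-fluorophenyl gives a 3.6-fold higher number from compound 3 to compound 4 (0.56 log units; beyond the scatter), so this change does not carry over unchanged between the two cores: the same change on two cores in this assay, a 1.1-fold higher number (0.05 log units; within the scatter) from compound 2 to compound 1 and a 3.6-fold higher number (0.56 log units; beyond the scatter) from compound 3 to compound 4, 3.2-fold (0.51 log units) apart, beyond the scatter of two such steps. Phenyl in place of benzyl on the oxygen gives a 1.1-fold lower number from compound 1 to compound 4 (0.05 log units; within the scatter), and it does not carry over unchanged either: the same change on two cores in this assay, a 3.6-fold lower number (0.56 log units; beyond the scatter) from compound 2 to compound 3 and a 1.1-fold lower number (0.05 log units; within the scatter) from compound 1 to compound 4, 3.2-fold (0.51 log units) apart, beyond the scatter of two such steps. Both gaps rest on compound 3, which lies below compound 2 and compound 4, so the two changes are not independent across these four compounds, but this does not show why or whether it holds on any other core.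

Still open, as far as these compounds go, is whether the low number of compound 3 is specific to the pairing of 4-fluorophenyl with the phenyl ether. Also open, from the compounds shown here alone, is how an amine or a longer chain on the saturated ring carbon would behave on either core.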